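The compounds below may be only part of what the source reports. "The series", "measured", "known", "first", "only" and "open" are said of these compounds alone.

Compound 2 `CCN1CCN(CCCSc2nnc(-c3ccc(C)cc3)[nH]2)CC1` sits at the weakest end of what has been measured. In a functional assay on U-937 cells (Homo sapiens) for cytotoxicity, read by MTT assay, with a stated time of 24 h (on this read-out lower numbers stand for stronger inhibition and higher numbers for weaker inhibition), compound 2 gives > 300000 nM, which is a limit of the assay rather than a number. Within the data shown here, compound 1 `Cc1ccc(-c2nnc(SCCCN3CCN(c4cccc(Cl)c4)CC3)[nH]2)cc1` gives 257000 nM in this assay, and the step of an at least 1.1-fold higher number from compound 1 to compound 2 (0.06 log units; that floor lies within the scatter) is the only measured step with one change. Compound 3 `Clc1cccc(-c2nnc(SCCCN3CCN(c4ncccn4)CC3)[nH]2)c1` gives 49100 nM in this assay, but it differs from compound 1 at two places, so only the two values themselves can be read. Compound 4 `CCN1CCN(CCCSc2nnc(-c3ccccc3Cl)[nH]2)CC1` differs from compound 2 by 2-chlorophenyl in place of 4-methylphenyl on an aromatic carbon. Among the measured compounds shown here, no measured step touches that aryl position, so no direction can be drawn from the data. Compound 4 is therefore expected near 250000 nM in this assay, with a range from 60000 nM to 800000 nM. The step of an at least 1.2-fold lower number from compound 2 to compound 4 (0.07 log units; that floor lies within the scatter) that this estimate implies is expected to lie within the scatter.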

Compound 4, half-maximal inhibitory concentration: > 300000 nM
Compound 4 was reported as a limit; the forecaster's own chance of this, stated with the estimate: 50%; at least 1.2-fold (0.07 log units) between middle value and limit.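

No step can be read from compound 2 to compound 4, because both stand at the same limit: the limit of > 300000 nM in this assay, at which 2 of the 4 values shown sit. As far as these compounds go, whether 2-chlorophenyl and 4-methylphenyl differ at all on that aromatic carbon remains open.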